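Swapping the Para Substituent on the Amide-Side Ring

The source may report more compounds than this note shows. Statements on the series, on what has been measured and on what is new or still open speak of the compounds shown alone.

Compound 2 `CN(C)CCC(NC(=O)CCc1ccc(C(F)(F)F)cc1)c1ccc(Cl)cc1` carries a trifluoromethyl group on its outer aromatic ring and, in a functional assay on NIH3T3 cells for agonist activity at Urotensin-2 receptor (Homo sapiens), with a stated time of 5 days (on this read-out higher numbers stand for an effect only at larger amounts of compound and lower numbers for an effect already at smaller amounts), compound 2 gives 1120 nM. Compound 1 `CN(C)CCC(NC(=O)CCc1ccccc1)c1ccc(Cl)cc1` has hydrogen in that place, and in this assay compound 1 gives 1660 nM. Among the two numbers measured so far, compound 2 shows the lower one, but the step of a 1.5-fold lower number from compound 1 to compound 2 (0.17 log units; within the scatter) falls within the usual scatter, so the two compounds cannot be told apart on this read-out.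

Compound 3 `COc1ccc(CCC(=O)NC(CCN(C)C)c2ccc(Cl)cc2)cc1` differs from compound 2 by methoxy in place of trifluoromethyl on an aromatic carbon. Among the measured compounds shown here, the only measured step at this position, a 1.5-fold lower number from compound 1 to compound 2 (0.17 log units; within the scatter), moved nothing beyond the scatter; this gives no reason to expect a change beyond the scatter for compound 3 in this assay, so the expected step is a 1.2-fold higher number from compound 2 to compound 3 (0.06 log units; within the scatter). Compound 3 is therefore estimated at 1300 nM, in a range from 450 nM to 3800 nM.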

Compound 3, half-maximal effective concentration: 2950 nM
For compound 3 the middle estimate is 2.3-fold (0.36 log units) below the measured one, and the stated range covers the measured number.
By their numbers in this assay, from the lowest: compounds 2, 1 and 3 (each within the scatter of the next, the first and the last beyond it).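

Among the compounds shown here, the position does respond to what sits on it: methoxy in place of trifluoromethyl gives a 2.6-fold higher number from compound 2 to compound 3 (0.42 log units; beyond the scatter), the first step to pass the scatter, though only a modest one. Methoxy in place of hydrogen gives a 1.8-fold higher number from compound 1 to compound 3 (0.25 log units; within the scatter), so compound 1 cannot be told apart from compound 3 or from compound 2, and only the two compounds with a group at this position lie apart in this assay. No measurement is available that explains the gap between trifluoromethyl and methoxy.

For the compounds shown here, with only three groups compared at this position, it remains open how an amine, a carboxylic acid or a longer chain such as butoxy would behave there. On these data alone, it is also open whether the same swap would give a step of similar size on a different core.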